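Swapping trifluoromethyl for hydroxy in a small series

The compounds below may be only part of what the source reports. "The series", "measured", "known", "first", "only" and "open" are said of these compounds alone.

Measured so far in a functional assay on HCT-116 cells (Homo sapiens) for antiproliferative activity, read by MTT assay, with a stated time of 72 h (a lower number here means a stronger inhibitor, a higher number a weaker inhibitor), for three compounds
compound 1 `C=CC(=O)Nc1nc(-c2ccccc2)cs1` gives 18600 nM
compound 2 `C=CC(=O)Nc1nc(-c2cccc(Cl)c2)cs1` gives 11900 nM
compound 3 `C=CC(=O)Nc1nc(-c2ccc(C(F)(F)F)cc2)cs1` gives 4000 nM

Of these, compound 3 at 4000 nM sits lowest, and its gaps to the other two both lie beyond the scatter. The next compound is compound 4 `C=CC(=O)Nc1nc(-c2ccc(O)cc2)cs1`, which has hydroxy in place of trifluoromethyl on an aromatic carbon, para to a large group. Counted out, the change is hydroxy in place of trifluoromethyl on an aromatic carbon and it touches nothing else in the molecule.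

The closest guide is a 4.7-fold lower number from compound 1 to compound 3 (0.67 log units; beyond the scatter), which came with trifluoromethyl in place of hydrogen on an aromatic carbon. Losing that group could give back much of this drop. The other measured step, a 1.6-fold lower number from compound 1 to compound 2 (0.19 log units; within the scatter), came with chloro in place of hydrogen and says little. Going by the values given here, no measured compound carries hydroxy, so the forecast stays loose. The expected change, toward a weaker inhibitor in this assay, is a 3.5-fold higher number from compound 3 to compound 4 (0.54 log units; beyond the scatter) by this estimate. The estimated value for compound 4 is 14000 nM with an expected range from 5000 nM to 40000 nM for now.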

Compound 4, half-maximal inhibitory concentration: 7100 nM
For compound 4 the middle estimate is 2.0-fold (0.29 log units) above the measured one; the measured number falls inside the stated range.
By their numbers in this assay, from the lowest: compounds 3, 4, 2 and 1 (each within the scatter of the next, the first and the last beyond it).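

Swapping trifluoromethyl for hydroxy gives a 1.8-fold higher number from compound 3 to compound 4 (0.25 log units; within the scatter) in this assay, so this exchange of four heavy atoms without a hydrogen-bond donor for one heavy atom with a donor leaves no gap that can be read. Measured against the hydrogen of the core, hydroxy at this place, para to a large group, gives a 2.6-fold lower number from compound 1 to compound 4 (0.42 log units; beyond the scatter), so two quite different groups here, in compound 3 and compound 4, both stand apart from compound 1, though the hydroxy step is modest. No measurement shown here explains why these two groups give such close numbers.

On these data alone, whether an amine, a methoxy group or a carboxylic acid at this same place would fit alongside them stays open. So does how hydroxy would read on the ring carbon that holds the chloro in compound 2.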